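The source may hold more compounds than are shown below. What is called first, only, known or untested is meant among the compounds shown, and "the series" means these compounds.

Working notes on the series. Compound 1 `CC1CCN(C2CCN(S(=O)(=O)c3cccc(N)c3)CC2)CC1` carries 3-aminophenyl on the sulfonyl sulfur of the shared core, compound 2 `CC1CCN(C2CCN(S(=O)(=O)c3cnc(Cl)s3)CC2)CC1` a 2-chloro-1,3-thiazol-5-yl, and compound 3 `COc1cccc(S(=O)(=O)N2CCC(N3CCC(C)CC3)CC2)c1` a 3-methoxyphenyl. In a functional assay on DLD-1 cells (Homo sapiens) for antiproliferative activity, read by CellTiter-Glo, with a stated time of 72 h (on this read-out lower numbers stand for stronger inhibition and higher numbers for weaker inhibition), compound 1 gives 3400 nM. In this assay compound 2 gives 1800 nM. For compound 3 this assay reports only a limit, > 5000 nM. Among the two numbers compound 2 stands lowest, compound 1 nearest; the step of a 1.9-fold lower number from compound 1 to compound 2 (0.28 log units; within the scatter) lies within the scatter, as does the floor of an at least 1.4-fold higher number from compound 1 to compound 3 (0.16 log units; that floor lies within the scatter). The step of an at least 2.7-fold higher number from compound 2 to compound 3 (0.44 log units; beyond the scatter) is at least modest; that it is a floor comes from the limit of > 5000 nM in this assay, at which 1 of the 3 values shown sits.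

Compound 4 `CC1CCN(C2CCN(S(=O)(=O)c3sc(Cl)nc3C3CC3)CC2)CC1` differs from compound 2 by cyclopropyl in place of hydrogen on an aromatic carbon. Within the data shown here, none of the measured steps touches an aromatic carbon of the five-membered ring; they exchange the whole group on the sulfonyl sulfur or swap amino for methoxy on an aromatic carbon, and run from within the scatter to at least modest. Among the measured compounds shown here, a group added at this place has no precedent. Compound 4 is therefore estimated at about 1800 nM in this assay, between 500 nM and 6000 nM. The expected step of no change at the digits printed from compound 2 to compound 4 (within the scatter) is accordingly no change beyond the scatter, with wide uncertainty.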

Compound 4, half-maximal inhibitory concentration: > 5000 nM
Compound 4: no number, only a limit (the forecaster's own chance of this, stated with the estimate: 25%); middle value at least 2.7-fold (0.44 log units) from the limit.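

In this assay, cyclopropyl in place of hydrogen on this aromatic carbon, next to the ring nitrogen, gives an at least 2.7-fold higher number from compound 2 to compound 4 (0.44 log units; beyond the scatter). This is the only step shown that adds a group to the five-membered aromatic ring rather than exchanging the whole group on the sulfonyl sulfur or swapping amino for methoxy, and it shows that this place does not tolerate every added group without a change beyond the scatter. Compound 4 retains the chloro group, so that group alone does not preserve the value seen for compound 2, but the value of compound 4 is a limit and the step gives only a floor: the limit of > 5000 nM in this assay, at which 2 of the 4 values shown sit.

From the compounds shown here alone, the full size of the step remains open, as does whether it belongs to cyclopropyl in particular or to any group at this place. Going by these compounds, what a methyl group, an amine or a longer chain would give on this aromatic carbon also remains open, as does whether the same change would give a similar step without the chloro group.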